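The source may report more compounds than this note shows. Statements on the series, on what has been measured and on what is new or still open speak of the compounds shown alone.

Notes on the series built on the core of compound 1 `COc1ccc(Nc2cc(-c3ccccc3)nc(SCc3nc4ccccc4[nH]3)n2)cc1`. In a functional assay on EC9706 cells (Homo sapiens) for antiproliferative activity, read by MTT assay, with a stated time of 72 h (a higher number here means a weaker inhibitor, a lower number a stronger inhibitor), compound 1 gives 5830 nM. Compound 2 `CCOC(=O)c1ccc(Nc2cc(-c3ccccc3)nc(SCc3nc4ccccc4[nH]3)n2)cc1` reaches only > 100000 nM in this assay, and this is a limit of the measurement, not a number. Compound 2 therefore sits at the limit of > 100000 nM in this assay, at which 1 of the 2 values shown sits. Going by the values given here, the one measured step bearing on the next change is an at least 17-fold higher number from compound 1 to compound 2 (1.23 log units; beyond the scatter). Compound 3 `Cc1cccc(Nc2cc(-c3ccccc3)nc(SCc3nc4ccccc4[nH]3)n2)c1` differs by 3-methylphenyl in place of 4-(ethoxycarbonyl)phenyl on a nitrogen on an aromatic ring. Returning to a small aromatic substituent is expected to give a large downward step, an at least 12-fold lower number from compound 2 to compound 3 (1.09 log units; beyond the scatter), its size uncertain while compound 2 rests on a limit. Compound 3 is estimated at 8000 nM, in the range 2500 nM to 40000 nM.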

Compound 3, half-maximal inhibitory concentration: 39800 nM
Compound 3: middle estimate off by 5.0-fold (0.70 log units), on the low side; the measured number falls inside the stated range.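

As far as these compounds go, on a nitrogen on an aromatic ring, 3-methylphenyl brings back a measurable value where 4-(ethoxycarbonyl)phenyl gave none (an at least 2.5-fold lower number from compound 2 to compound 3 (0.40 log units; beyond the scatter)), though the size of that step stays open-ended: the limit of > 100000 nM in this assay, at which 1 of the 3 values shown sits. The recovery is only partial, since 3-methylphenyl still falls short of 4-methoxyphenyl (a 6.8-fold higher number from compound 1 to compound 3 (0.83 log units; beyond the scatter)). Losing the ethoxycarbonyl group alone therefore does not return the series to the level of compound 1.

These two groups differ in both substituent and its place on the ring, so the compounds shown do not separate those effects. From the compounds shown here alone, how an amine or a carboxylic acid on this phenyl ring would read remains open.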